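Amide chain homologation in a weakly antiproliferative furan series

A few compounds are considered here, and "the series" means these few. Any claim that something is new, unique, unknown or untested is made for them only; others in the source may bear on it.

Measured so far:
compound 1 `CCNC(=O)c1oc2nc(-c3ccccc3)cc(C(F)(F)F)c2c1N` gives 70000 nM
compound 2 `CCNC(=O)c1oc2nc(-c3cccs3)cc(C(F)(F)F)c2c1N` gives 62000 nM

Both compounds were run in an ADME assay on HEK293 cells (Homo sapiens) for antiproliferative activity, read by MTT assay; a higher number here means a weaker inhibitor, a lower number a stronger inhibitor. Among the measured compounds shown here, compound 2 and compound 1 lie within the scatter of each other, the only measured step being a 1.1-fold lower number from compound 1 to compound 2 (0.05 log units; within the scatter). Compound 2 therefore cannot be placed above or below compound 1 on these numbers; the two are indistinguishable.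

Compound 3 `CCCNC(=O)c1oc2nc(-c3cccs3)cc(C(F)(F)F)c2c1N` is the next step from compound 2: methyl in place of hydrogen on a saturated chain carbon, two bonds along the chain from an amide-type nitrogen. For the measured compounds named here, no measured step bears on this change. Going by the values given here, the single step recorded in this assay alters the aromatic substituent on the shared core, not the amide chain, so it gives no guide to the ethyl-to-propyl homologation. With nothing to suggest a shift, the expected step for compound 3 is none beyond the scatter, a 1.0-fold lower number from compound 2 to compound 3 (0.01 log units; within the scatter). Compound 3 is thus estimated at 60000 nM in this assay, with a range of 30000 nM to 120000 nM.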

Compound 3, half-maximal inhibitory concentration: 64000 nM
Compound 3: middle estimate off by 1.1-fold (0.03 log units), on the low side, within the range that was stated.
By their numbers in this assay, from the lowest: compounds 2, 3 and 1 (each within the scatter of the next).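

Ethyl to propyl gives the first reading at this position of the amide chain: in this assay the step is a 1.0-fold higher number from compound 2 to compound 3 (0.01 log units; within the scatter). The methyl entering on the saturated chain carbon, two bonds along the chain from an amide-type nitrogen, therefore leaves the number without a readable change, something the earlier step on the aromatic substituent could not show. No supporting measurement bears on this result, so the flat step stands unexplained.

Still open, on these data alone, is whether a longer chain such as butyl, or a chain ending in an amine or a carboxylic acid, would move the number beyond the scatter. Also open, as far as these compounds go, is whether the ethyl-to-propyl change reads the same with phenyl in place of thiophen-2-yl on the shared core.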